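Moving both chlorines on the arylidene ring of compound 3

The source may report more compounds than this note shows. Statements on the series, on what has been measured and on what is new or still open speak of the compounds shown alone.

In a functional assay on MGC-803 cells (Homo sapiens) for inhibition, read by MTT assay, with a stated time of 72 h, tested at 10 uM (on this read-out higher numbers stand for more inhibition of growth at the one concentration tested and lower numbers for less inhibition of growth), compound 1 `O=C(/C=C/c1ccc(Oc2ncnc3ccc(Cl)cc23)cc1)/C=C/c1cc([N+](=O)[O-])ccc1Cl` gives 86.7% and compound 2 `O=C(/C=C/c1ccc(Oc2ncnc3ccc(Cl)cc23)cc1)/C=C/c1ccc(Cl)c([N+](=O)[O-])c1` gives 66.2%. Compound 3 `O=C(/C=C/c1ccc(Oc2ncnc3ccc(Cl)cc23)cc1)/C=C/c1ccc(Cl)c(Cl)c1` is the lowest of the three, giving 50.5% in this assay. The step from compound 1 to compound 2 shows that exchanging the positions of the chloro and nitro groups is worth a number 20.5 percentage points lower from compound 1 to compound 2 (beyond the scatter), and replacing nitro by chloro gives a number 15.7 percentage points lower from compound 2 to compound 3 (beyond the scatter), so that a number 36.2 percentage points lower from compound 1 to compound 3 (beyond the scatter) separates the two ends of the series.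

Compound 4 `O=C(/C=C/c1ccc(Oc2ncnc3ccc(Cl)cc23)cc1)/C=C/c1cccc(Cl)c1Cl` differs from compound 3 only by the change (2,3-dichlorophenyl in place of 3,4-dichlorophenyl on a double-bonded chain carbon bound to a double-bonded chain carbon). Going by the values given here, no measured pair exchanges two chlorines in this way, so the only guide is the step from compound 1 to compound 2, where rearranging the same substituents on this ring shifted this assay by a modest amount. The account therefore expects a modest step in a number 6.5 percentage points higher from compound 3 to compound 4 (within the scatter), upward if anything, since compound 1, with a chloro group on the first carbon of its ring, gave the highest number at 86.7%. For compound 4 the expected value in this assay is 57%, within a range from 42% to 74%.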

Compound 4, percent growth inhibition at one concentration: 68.5%
Beside the measured number, compound 4's estimate is 11.5 percentage points below it; low and high end bracket the measured number.
By their numbers in this assay, from the lowest: compound 3; then compounds 2 and 4 (each within the scatter of the next); then compound 1.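

Here the same two chlorines move on the ring with no atom gained or lost, and in this assay this change alone gives a number 18 percentage points higher from compound 3 to compound 4 (beyond the scatter), so the arrangement on this ring matters even with no nitro group present. The 2,3-dichlorophenyl ring also comes level with the 4-chloro-3-nitrophenyl ring, with a number 2.3 percentage points higher from compound 2 to compound 4 (within the scatter), which shows that among these compounds a nitro group is not required to reach the level of compound 2, although a number 18.2 percentage points lower from compound 1 to compound 4 (beyond the scatter) leaves the 2-chloro-5-nitrophenyl ring of compound 1 clearly ahead. No measurement offered here explains why one arrangement of the two chlorines differs from the other.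

The compounds shown leave open how a 2,3-difluorophenyl or a 2,3-dimethoxyphenyl ring would stand in this assay, and whether an amino group in place of the nitro group of compound 1 would hold its number. They also leave open whether the order seen at this one concentration in these cells would hold over a full range of concentrations.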